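A few compounds are considered here, and "the series" means these few. Any claim that something is new, unique, unknown or untested is made for them only; others in the source may bear on it.

Going by the values given here, in an ADME assay on Vero cells (Chlorocebus sabaeus) for cytotoxicity, read by resazurin assay, with a stated time of 72 h (on this read-out higher numbers stand for weaker inhibition and lower numbers for stronger inhibition), compound 1 (`COc1ccc(C(=O)CCN2CCN(c3ccc(F)cc3)CC2)cc1`) gives 55000 nM, the lower of the two numbers measured so far. Among the compounds with values here, the only other measured compound, compound 2 (`COc1ccc(C(=O)CCN2CCN(c3ccc(Cl)cc3)CC2)cc1`), gives 300000 nM. Compound 3 (`COc1ccc(C(=O)CCN2CCN(c3ccc(F)cc3)CC2)cc1OC`) keeps the fluoro of compound 1 and differs elsewhere: methoxy in place of hydrogen on an aromatic carbon. In words, this is methoxy in place of hydrogen on an aromatic carbon, ortho to a methoxy group and meta to a large group. Within the data shown here, the one measured step, a 5.5-fold higher number from compound 1 to compound 2 (0.74 log units; beyond the scatter), came from chloro in place of fluoro, so it bears on this change only indirectly. It shows that one substitution can move the number in this assay by a modest amount, but it involves a different group at a different place and gives no direction for an added methoxy. Among the measured compounds shown here, no measured step involves a methoxy group being added. Only a small shift towards a higher number is therefore expected, and it may stay within the scatter. The expected step is a 1.5-fold higher number from compound 1 to compound 3 (0.16 log units; within the scatter). For compound 3 the estimated value is 80000 nM, with an expected range from 25000 nM to 250000 nM.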

Compound 3, half-maximal inhibitory concentration: 175000 nM
Compound 3: middle estimate off by 2.2-fold (0.34 log units), on the low side; the range from low to high includes it.
By their numbers in this assay, from the lowest: compound 1; then compounds 3 and 2 (each within the scatter of the next).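

In this assay, methoxy in place of hydrogen on an aromatic carbon, ortho to a methoxy group and meta to a large group, gives a shift beyond the scatter (a 3.2-fold higher number from compound 1 to compound 3 (0.50 log units; beyond the scatter)), so this position does respond to substitution, and by more than the small shift within the scatter that might have been supposed. Alongside the earlier step (a 5.5-fold higher number from compound 1 to compound 2 (0.74 log units; beyond the scatter)), it shows that changes in two different places of compound 1, chloro in place of fluoro and methoxy in place of hydrogen, both give a higher number, and compound 1 keeps the lowest number of the three. Nothing measured here accounts for the size or direction of this shift.

From the compounds shown here alone, what a hydroxyl group, an amine or a carboxylic acid would do at the same aromatic carbon stays open, as does whether a methoxy group at another carbon of this ring would give a similar step. Also open, going by these compounds, is whether the added methoxy group would move the number in the same direction with chloro in place of fluoro.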